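Adding an Amino Group to a Weak Kinase Inhibitor

This account rests on a few compounds, and the source may have more. Where it says the series, first, only, none or still open, it means among the compounds named here.

Measured compounds:
Compound 1 `O=S(=O)(Nc1cc(-c2ccc3nc[nH]c3c2)cnc1Cl)c1ccc(F)cc1`: > 12000 nM
Compound 2 `O=S(=O)(Nc1cc(-c2ccc3sncc3c2)cnc1Cl)c1ccc(F)cc1`: > 12000 nM

In an assay on U-87MG ATCC cells for inhibition of RAC-alpha serine/threonine-protein kinase (Homo sapiens), read by AlphaScreen, with a stated time of 2 h (on this read-out higher numbers stand for weaker inhibition and lower numbers for stronger inhibition), compound 1 reaches only a limit of the assay, > 12000 nM. Compound 2 likewise gives only a limit, > 12000 nM. The step that the two limits leave unreadable from compound 1 to compound 2 cannot be read because both values sit at the limit of > 12000 nM in this assay, at which 2 of the 2 values shown sit.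

Compound 3 `Nc1nc2ccc(-c3cnc(Cl)c(NS(=O)(=O)c4ccc(F)cc4)c3)cc2[nH]1` differs from compound 1 by amino in place of hydrogen on an aromatic carbon. Among the compounds with values here, no measured step touches this change, so the only footing is that compound 1 stands at a limit. The expected step is a number no higher from compound 1 to compound 3 (the limit leaves the size open). For compound 3 the estimate is 12000 nM, with a range from 2000 nM to 50000 nM.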

Compound 3, half-maximal inhibitory concentration: > 12000 nM
Compound 3: a limit, no number; the forecaster's own chance of this, stated with the estimate: 60%; the middle value lies on the limit itself.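

In this assay compound 3 gives > 12000 nM as well, a limit and not a number. The step from compound 1 to compound 3 therefore cannot be read, because all the values sit at one limit: the limit of > 12000 nM in this assay, at which 3 of the 3 values shown sit.

The compounds shown leave open whether amino in place of hydrogen changes inhibition at all, and how strongly any of them inhibits.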